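Benzyl Aryl Swaps on a Bis(trifluoromethyl) Sulfonamide Scaffold

This account rests on a few compounds, and the source may have more. Where it says the series, first, only, none or still open, it means among the compounds named here.

Measured so far:
Compound 1 `O=S(=O)(NCCCNCc1ccc(Cl)c(Cl)c1)c1cc(C(F)(F)F)cc(C(F)(F)F)c1` gives 2700 nM in a functional assay on MIA PaCa-2 cells (Homo sapiens) for inhibition, read by MTT assay, with a stated time of 72 h; on this read-out lower numbers stand for stronger inhibition of growth and higher numbers for weaker inhibition of growth.
Compound 2 `COc1ccc(CNCCCNS(=O)(=O)c2cc(C(F)(F)F)cc(C(F)(F)F)c2)cc1OC` gives 2800 nM in this assay.
Compound 3 `O=S(=O)(NCCCNCc1ccc(C(F)(F)F)cc1)c1cc(C(F)(F)F)cc(C(F)(F)F)c1` gives 2500 nM in this assay.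

The three compounds share a core and differ only in the aryl group carried on the saturated chain carbon bound to the amine nitrogen. Compound 3 sits together with compound 1 and compound 2 inside the scatter of a single value: a 1.1-fold lower number from compound 1 to compound 3 (0.03 log units; within the scatter) and a 1.1-fold lower number from compound 2 to compound 3 (0.05 log units; within the scatter), and between the other two a 1.0-fold higher number from compound 1 to compound 2 (0.02 log units; within the scatter). The swaps of 3,4-dichlorophenyl, 3,4-dimethoxyphenyl and 4-(trifluoromethyl)phenyl move nothing beyond the scatter.

Compound 4 `O=S(=O)(NCCCNCc1ccc(-c2ccccc2)cc1)c1cc(C(F)(F)F)cc(C(F)(F)F)c1` has not been measured. It differs from compound 3 in one place: phenyl in place of trifluoromethyl on an aromatic carbon. Among the measured compounds shown here, no measured step changes this position directly; the nearest guidance is the whole-aryl exchanges among compound 1, compound 2 and compound 3, each of which was within the scatter. The expectation for compound 4 in this assay is therefore a step of no change at the digits printed from compound 3 to compound 4 (within the scatter), not beyond the scatter, in no firm direction. Compound 4 is estimated at 2500 nM, with a range from 1000 nM to 6500 nM.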

Compound 4, concentration for 50% growth inhibition: 2400 nM
The estimate for compound 4 lay 1.0-fold (0.02 log units) above the measured number; the measured number falls inside the stated range.
By their numbers in this assay, from the lowest: compounds 4, 3, 1 and 2 (each within the scatter of the next).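

In this assay the exchange on this aromatic carbon, para to a large group, gives a 1.0-fold lower number from compound 3 to compound 4 (0.02 log units; within the scatter) and so leaves the read-out unchanged within the scatter. Among the compounds shown here, the earlier compounds differed by whole aryl groups, so this is the first step confined to a single substituent on the aryl ring, and the first to place a second aromatic ring there: phenyl, a six-membered aromatic ring of carbon only with 6 heavy atoms, enters where trifluoromethyl with its 4 heavy atoms leaves. Nothing at hand explains why a change of this size leaves the number within the scatter.

As far as these compounds go, whether an amine or a carboxylic acid on this same aromatic carbon would carry the number beyond the scatter remains open, since both groups entering here so far, trifluoromethyl and phenyl, have 0 hydrogen-bond donors and 0 hydrogen-bond acceptors. Also open, from the compounds shown here alone, is whether a longer chain in the shared core, or a change to the bis(trifluoromethyl) aryl group on the sulfonamide, would move the number where these aryl exchanges have not.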